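The source may hold more compounds than are shown below. What is called first, only, known or untested is meant among the compounds shown, and "the series" means these compounds.

In a functional assay on HT-29 cells (Homo sapiens) for inhibition, read by MTT assay, with a stated time of 48 h (a higher number here means a weaker inhibitor, a lower number a stronger inhibitor), compound 1 (`COc1cc(/C=C/c2ccc(NC(=O)/C=C/c3ccc(OC)c(OC)c3)cc2)cc(OC)c1`) gives 960 nM and compound 2 (`COc1cc(/C=C/c2ccc(NC(=O)/C=C/c3cc(OC)c(OC)c(OC)c3)cc2)cc(OC)c1`) gives 1820 nM while compound 3 (`COc1cc(/C=C/c2ccc(NC(=O)/C=C/c3ccc(C(F)(F)F)cc3)cc2)cc(OC)c1`) gives 1780 nM as a value within the scatter of both others. The three values do not separate on these data. Compound 4 (`COc1cc(/C=C/c2ccc(NC(=O)/C=C/c3cccc(F)c3)cc2)cc(OC)c1`) is not yet measured. Among the measured compounds shown here, its change from compound 3 reads (3-fluorophenyl in place of 4-(trifluoromethyl)phenyl on a double-bonded chain carbon bound to a double-bonded chain carbon) and 3-fluorophenyl appears in no measured compound. The closest evidence lies at the same place: 4-(trifluoromethyl)phenyl in place of 3,4-dimethoxyphenyl gave a 1.9-fold higher number from compound 1 to compound 3 (0.27 log units; within the scatter) as its result. The other measured change, methoxy in place of hydrogen on an aromatic carbon, gave a 1.9-fold higher number from compound 1 to compound 2 (0.28 log units; within the scatter) as its result. Neither step leaves the scatter, so no step beyond the scatter is expected in this assay for this replacement, and no direction can be called. The estimated step is a 1.2-fold lower number from compound 3 to compound 4 (0.07 log units; within the scatter) and it is expected to stay within the scatter. Compound 4 is expected at 1500 nM with an estimated range from 700 nM to 3200 nM for repeat measurements.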

Compound 4, half-maximal inhibitory concentration: 16800 nM
The estimate for compound 4 lay 11-fold (1.05 log units) below the measured number; the measured number lies above the stated range.
By their numbers in this assay, from the lowest: compounds 1, 3 and 2 (each within the scatter of the next); then compound 4.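

At the double-bonded chain carbon bound to a double-bonded chain carbon, replacing the aromatic group now produces steps beyond the scatter in this assay. 3-Fluorophenyl in place of 4-(trifluoromethyl)phenyl gives a 9.4-fold higher number from compound 3 to compound 4 (0.97 log units; beyond the scatter), and 3-fluorophenyl in place of 3,4-dimethoxyphenyl gives an 18-fold higher number from compound 1 to compound 4 (1.24 log units; beyond the scatter). This place therefore responds to the group it carries, which compound 1, compound 2 and compound 3 alone did not show, and no measurement on hand bears on why.

3-Fluorophenyl occurs only in compound 4, so one compound carries the whole finding and it stays unclear how far it extends to other groups. Also open, going by these compounds, is whether an unsubstituted phenyl, or a phenyl carrying an amine or a carboxylic acid, would read like compound 1 and compound 3 or like compound 4.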